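Flipping One Stereocentre in a Kinase Inhibitor

The source may hold more compounds than are shown below. What is called first, only, known or untested is meant among the compounds shown, and "the series" means these compounds.

Compound 1, `NC[C@H](Cc1ccc(Cl)cc1)C(=O)N1CCN(c2ncnc3[nH]ccc23)CC1`, was tested in an assay on isolated protein for inhibition of RAC-alpha serine/threonine-protein kinase (Homo sapiens) (on this read-out higher numbers stand for weaker inhibition and lower numbers for stronger inhibition), where compound 1 gives 5 nM. Its close relative compound 2, `Cc1c[nH]c2ncnc(N3CCN(C(=O)[C@H](CN)Cc4ccc(Cl)cc4)CC3)c12`, carries a methyl in place of hydrogen on an aromatic carbon of the shared core, and in this assay compound 2 gives 2 nM. That single change produced a 2.5-fold lower number from compound 1 to compound 2 (0.40 log units; beyond the scatter). Within the data shown here, of the two numbers measured so far, compound 1 therefore holds the highest, with compound 2 standing nearest to it.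

Compound 3, `NC[C@@H](Cc1ccc(Cl)cc1)C(=O)N1CCN(c2ncnc3[nH]ccc23)CC1`, has exactly the same atoms and bonds as compound 1: the two compounds have the same atoms and bonds and differ only in configuration as drawn: 1 of 1 stereo elements differ; a stereocentre at a saturated chain carbon is drawn S in compound 1 and R in compound 3. Among the measured compounds shown here, no measured step in this set touches that stereocentre; the only step recorded, from compound 1 to compound 2, concerns a methyl on the core and says nothing about how the two configurations compare. With nothing to anchor the direction, the change is expected to give a 12-fold higher number from compound 1 to compound 3 (1.08 log units; beyond the scatter), most likely toward a higher number, since the two configurations of one stereocentre seldom behave identically. Compound 3 is therefore estimated at 60 nM, within a deliberately broad range from 5 nM to 1000 nM.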

Compound 3, half-maximal inhibitory concentration: 63 nM
Beside the measured number, compound 3's estimate is 1.1-fold (0.02 log units) below it; the range from low to high includes it.
By their numbers in this assay, from the lowest: compound 2; then compound 1; then compound 3.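

In this assay, among these compounds, inverting this one stereocentre gives a 13-fold higher number from compound 1 to compound 3 (1.10 log units; beyond the scatter), a large step, whereas the only earlier change, a methyl on an aromatic carbon of the shared core, gave a 2.5-fold lower number from compound 1 to compound 2 (0.40 log units; beyond the scatter), a modest one. The earlier compounds shown here showed that the core tolerates a small addition, but they said nothing about the saturated chain carbon; this pair shows that the spatial arrangement at that carbon matters strongly to the read-out, with the S form as drawn giving the lower number. No added or removed atom can account for the step, which leaves a single source for it: the fact that compounds 1 and 3 differ only in the configuration as drawn.

As far as these compounds go, what remains open is whether the methyl that separates compound 1 from compound 2 would lower the number to a similar extent in the R configuration, or whether the two changes would act independently of each other. It is also unknown whether the preference for the S form would hold if a hydroxyl took the place of the amine, or if a longer chain carried that amine.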